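Formylamino to Methoxycarbonylamino: Expecting Another Limit

The source may report more compounds than this note shows. Statements on the series, on what has been measured and on what is new or still open speak of the compounds shown alone.

Compound 2, `O=CNC[C@H]1CN(c2ccc(-n3cc(-c4ccccn4)cn3)c(F)c2)C(=O)O1`, carries a formylamino group on its side chain. In an ADME assay on L02 cells (Homo sapiens) for cytotoxicity, read by MTT assay, with a stated time of 48 h (a higher number here means a weaker inhibitor, a lower number a stronger inhibitor), compound 2 gives > 400 ug/mL, which is a limit of the assay rather than a measured number. Its close relative compound 1, `O=C1O[C@@H](CSc2cccs2)CN1c1ccc(-n2cc(-c3ccccn3)cn2)c(F)c1`, differs only at that side chain. In this assay compound 1 gives > 400 ug/mL, again a limit and not a number. The step that the two limits leave unreadable from compound 1 to compound 2 therefore cannot be sized in either direction. Compound 3, `COC(=O)NC[C@H]1CN(c2ccc(-n3cc(-c4ccccn4)cn3)c(F)c2)C(=O)O1`, is the next member: it differs from compound 2 by methoxy in place of hydrogen on a carbonyl carbon, so the formylamino group becomes a (methoxycarbonyl)amino group. For the measured compounds named here, only one measured step touches this part of the molecule, and it is unreadable, so no size can be carried over. What remains is the limit of > 400 ug/mL in this assay, at which 2 of the 2 values shown sit, which places every measured value of this small series at the same limit. Against that background the step that the limit leaves unreadable from compound 2 to compound 3 is expected to be small. Compound 3 is expected to give about 500 ug/mL in this assay, within 250 ug/mL to 1000 ug/mL, most likely reported once more as a limit rather than a number.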

Compound 3, half-maximal inhibitory concentration: 71 ug/mL
Compound 3: the middle estimate sits 7.0-fold (0.85 log units) above what was measured; the measured number lies below the stated range.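

Methoxy in place of hydrogen on a carbonyl carbon, which turns formylamino into (methoxycarbonyl)amino, gives an at least 5.6-fold lower number from compound 2 to compound 3 (0.75 log units; beyond the scatter) in this assay, so a change of this small size at this position is enough to move the read-out towards a stronger inhibitor of these cells. Replacing the side chain of compound 1 gives an at least 5.6-fold lower number from compound 1 to compound 3 (0.75 log units; beyond the scatter), and like the first step this one sets only a minimum size, with the true gap possibly much wider. The step between compound 1 and compound 2 cannot be read, and compound 3 is the only one of the series with a real number rather than a limit: the limit of > 400 ug/mL in this assay, at which 2 of the 3 values shown sit.

The compounds shown leave open whether ethoxy on the same carbonyl carbon, or methyl in place of the methoxy, would also bring the number down, so a single result cannot yet say how the number follows the group at this place. For the compounds shown here, with only one real number, no trend can be drawn, and how far compound 1 and compound 2 truly lie from compound 3 remains unknown.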